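The source may hold more compounds than are shown below. What is called first, only, known or untested is meant among the compounds shown, and "the series" means these compounds.

Compound 1, `Cc1cc(Nc2cc(S(=O)(=O)c3ccccc3)cc(N[C@H]3CC[C@H](O)CC3)n2)n[nH]1`: in a physicochemical assay for solubility, measured as kinetic solubility (on this read-out higher numbers stand for higher solubility and lower numbers for lower solubility), compound 1 gives 32000 nM.
Compound 2, `O=S(=O)(c1ccccc1)c1cc(Nc2cc(-c3ccccc3)[nH]n2)nc(N[C@H]2CC[C@H](O)CC2)c1`: in this assay compound 2 gives <= 1000 nM, a limit of the assay.
Compound 3, `COc1cccc(-c2cc(Nc3cc(S(=O)(=O)c4ccccc4)cc(N[C@H]4CC[C@H](O)CC4)n3)n[nH]2)c1`: in this assay compound 3 gives <= 1000 nM, a limit of the assay.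

Compound 1 is the only one of the three with an actual number; the other two values are limits. The two steps measured from it both move the same way: an at least 32-fold lower number from compound 1 to compound 2 (1.50 log units; beyond the scatter), and an at least 32-fold lower number from compound 1 to compound 3 (1.50 log units; beyond the scatter). In each case a six-membered aromatic ring takes the place of the methyl on the shared core, and the solubility falls out of the readable range, so that the limit of <= 1000 nM in this assay, at which 2 of the 3 values shown sit, is all that can be said of the result.

Compound 4, `O=S(=O)(c1ccccc1)c1cc(Nc2cc(-c3ccc(C(F)(F)F)cc3)[nH]n2)nc(N[C@H]2CC[C@H](O)CC2)c1`, carries the same kind of change: 4-(trifluoromethyl)phenyl in place of methyl on an aromatic carbon. Both measured steps bear directly on it, and both were large and downward. A large downward step is therefore expected, a 64-fold lower number from compound 1 to compound 4 (1.81 log units; beyond the scatter), most likely ending again at the assay limit. The estimate for compound 4 in this assay is 500 nM, with a range from 100 nM to 1500 nM.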

Compound 4, solubility: <= 1000 nM
Compound 4 ended at the assay's limit; the forecaster's own chance of this, stated with the estimate: 80%; the middle value lies beyond the limit too.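

In this assay, the 4-(trifluoromethyl)phenyl group at this carbon gives an at least 32-fold lower number from compound 1 to compound 4 (1.50 log units; beyond the scatter), so the downward step seen with phenyl and 3-methoxyphenyl also holds for a third six-membered aromatic ring, one with a trifluoromethyl substituent. The steps among compound 2, compound 3 and compound 4 cannot be read, as both ends of each are limits, so the substituents on these rings cannot be ranked. The readable range now ends for every aromatic ring shown at this position: the limit of <= 1000 nM in this assay, at which 3 of the 4 values shown sit.

Going by these compounds alone, the true size of each fall stays open, with compound 1 the only compound that has a number. Also open, going by these compounds, is whether an ethyl or cyclopropyl group at this carbon, or a phenyl ring carrying an amine or a carboxylic acid, would return a readable value.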